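This account rests on a few compounds, and the source may have more. Where it says the series, first, only, none or still open, it means among the compounds named here.

Measured so far: compound 1 `ClCc1ccccc1Cn1cnc2ncnc(Cl)c21` and compound 2 `Nc1nc(Cl)c2ncn(Cc3cccc(CCl)c3)c2n1`.

In a functional assay on MDA-MB-231 cells (Homo sapiens) for cytotoxicity, read by sulforhodamine B assay, with a stated time of 48 h (a higher number here means that more compound is tolerated, a lower number that less compound is tolerated), compound 1 gives 25100 nM, the lower of the two numbers; in this assay compound 2 gives 69200 nM, a number that stands beyond the scatter from that of compound 1. Compound 3 `ClCc1ccccc1Cn1cnc2nc(Cl)nc(Cl)c21` has not been measured in this assay. It differs from compound 1 by chloro in place of hydrogen on an aromatic carbon. Among the measured compounds shown here, no measured pair shows this change, so no step of a definite size is known; no change beyond the scatter is expected here. For compound 3 in this assay the estimate is 20000 nM, between 8000 nM and 50000 nM, an expected step of a 1.3-fold lower number from compound 1 to compound 3 (0.10 log units; within the scatter).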

Compound 3, concentration lethal to 50% of the cells: 3230 nM
Compound 3: middle estimate off by 6.2-fold (0.79 log units), on the high side; the measured number lies below the stated range.
By their numbers in this assay, from the lowest: compound 3; then compound 1; then compound 2.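

The place between two ring nitrogen atoms turns out to be sensitive to substitution: in this assay, chloro in place of hydrogen on this aromatic carbon gives a 7.8-fold lower number from compound 1 to compound 3 (0.89 log units; beyond the scatter). Among the compounds shown here, this one pair is the first to show a change at this place beyond the scatter, and nothing measured here accounts for its size. The compounds shown leave open whether a methyl, methoxy or fluoro group on this carbon would shift the number in the same way. They also leave open whether the step holds beyond this single pair.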